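Methoxy in Place of Methylsulfanyl on the Second Core

The source may hold more compounds than are shown below. What is called first, only, known or untested is meant among the compounds shown, and "the series" means these compounds.

In a functional assay on the whole organism for inhibition, with Digitaria ciliaris as the target, with a stated time of 72 h, tested at 10 mg/L (on this read-out lower numbers stand for less inhibition of growth and higher numbers for more inhibition of growth at the one concentration tested), the three measured compounds gave the following numbers:

Compound 1 `COc1cc(C)nc2n/c(=N/C(=O)c3c(-c4ccc(Cl)cc4Cl)noc3C)sn12`: 50.3%
Compound 2 `COc1cc(SC)nc(NC(=S)NC(=O)c2c(-c3ccc(Cl)cc3Cl)noc2C)n1`: 34.8%
Compound 3 `CSc1cc(C)nc2n/c(=N/C(=O)c3c(-c4ccc(Cl)cc4Cl)noc3C)sn12`: 26.8%

Compound 2 stands second of the three numbers in this assay. Its gap to compound 3 lies within the scatter, so the two cannot be ordered; compound 1 sits higher than compound 2 by a gap beyond the scatter.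

Compound 4 `COc1cc(OC)nc(NC(=S)NC(=O)c2c(-c3ccc(Cl)cc3Cl)noc2C)n1` has not yet been measured. It differs from compound 2 in one place: methoxy in place of methylsulfanyl on an aromatic carbon. Put more fully, the change is methoxy in place of methylsulfanyl on an aromatic carbon, on a six-membered aromatic ring with two nitrogens, next to the ring nitrogen and meta to a methoxy group.

For the measured compounds named here, one measured step bears on this change, in the opposite direction and on the other core: a number 23.5 percentage points lower from compound 1 to compound 3 (beyond the scatter). Reversing that direction, a rise in this assay is expected for compound 4, of a size similar to that step but with less certainty, since the core differs. The expected step is a number 15.2 percentage points higher from compound 2 to compound 4 (beyond the scatter). Compound 4 is therefore estimated at 50%, with a range from 32% to 68%.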

Compound 4, percent growth inhibition at one concentration: 32%
Beside the measured number, compound 4's estimate is 18 percentage points above it; the measured number falls inside the stated range.
By their numbers in this assay, from the lowest: compounds 3, 4 and 2 (each within the scatter of the next); then compound 1.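

In this assay, exchanging methylsulfanyl for methoxy on the 4-methoxy-6-(methylsulfanyl)pyrimidin-2-yl group gives a number 2.8 percentage points lower from compound 2 to compound 4 (within the scatter), so on this core the change has no effect that can be told apart from ordinary measurement noise. For the compounds shown here, the earlier pair showed only that this exchange can matter on the core of compound 1, and the new pair shows that its effect there does not carry over to the core of compound 2: the same change on two cores in this assay, a number 23.5 percentage points lower (beyond the scatter) from compound 1 to compound 3 and a number 2.8 percentage points higher (within the scatter) from compound 4 to compound 2, 26.3 percentage points apart, beyond the scatter of two such steps. In this assay, then, a step measured at this kind of position on one core is a poor guide to the same exchange on the other, at least for these two pairs.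

The compounds shown do not say why the two cores respond so differently, since a gap between two steps records the difference without giving a reason for it. Going by these compounds, it also remains open whether a group further from these two, such as a dimethylamino group or a longer ethoxy chain, would move the number beyond the scatter at this position on the core of compound 2.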